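Moving the hydroxyl on a chalcone-like boron compound

A few compounds are considered here, and "the series" means these few. Any claim that something is new, unique, unknown or untested is made for them only; others in the source may bear on it.

Measured so far:
Compound 1 `O=C(/C=C/c1ccc2c(c1)B(O)OC2)c1cccs1` gives 26000 nM in a toxicity assay on WI-38 cells (Homo sapiens) for cytotoxicity, read by MTT assay, with a stated time of 48 h; on this read-out higher numbers stand for weaker inhibition and lower numbers for stronger inhibition.
Compound 2 `Cc1cccc(C(=O)/C=C/c2ccc3c(c2)B(O)OC3)c1` gives 16700 nM in this assay.
Compound 3 `O=C(/C=C/c1ccc2c(c1)B(O)OC2)c1ccccc1O` gives > 100000 nM in this assay, which is a limit of the assay, not a number.

Compound 3 therefore stands at the weak end of the numbers shown: the step of an at least 3.8-fold higher number from compound 1 to compound 3 (0.58 log units; beyond the scatter) and the step of an at least 5.9-fold higher number from compound 2 to compound 3 (0.77 log units; beyond the scatter) both run beyond the scatter, and compound 3 is the one compound that sits at the limit of > 100000 nM in this assay, at which 1 of the 3 values shown sits. Compound 1 and compound 2 differ by a 1.6-fold lower number from compound 1 to compound 2 (0.19 log units; within the scatter), which stays within the scatter.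

Compound 4 `O=C(/C=C/c1ccc2c(c1)B(O)OC2)c1cccc(O)c1` has not yet been measured. It differs from compound 3 by 3-hydroxyphenyl in place of 2-hydroxyphenyl on a carbonyl carbon. Among the measured compounds shown here, no measured step moves the hydroxyl from one position to another, so the two steps that bear on it only show that the 2-hydroxyphenyl group pushed the number past the limit, while a 3-methylphenyl or thiophen-2-yl group stayed well inside the measured range. Whether the 3-hydroxyphenyl group behaves like the first or the second cannot be read from these three compounds.

For compound 4 a number between the two groups is expected, around 55000 nM, with a range from 18000 nM to 150000 nM. This expected estimate means a step of an at least 1.8-fold lower number from compound 3 to compound 4 (0.25 log units; that floor lies within the scatter) from compound 3 to compound 4.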

Compound 4, half-maximal inhibitory concentration: 26400 nM
The estimate for compound 4 lay 2.1-fold (0.32 log units) above the measured number; measured number inside the range.
By their numbers in this assay, from the lowest: compounds 2, 1 and 4 (each within the scatter of the next). At a limit, above all of these: compound 3.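

Moving the hydroxyl keeps the same atoms and the same counts of donors and acceptors, yet 3-hydroxyphenyl in place of 2-hydroxyphenyl brings an at least 3.7-fold lower number from compound 3 to compound 4 (0.57 log units; beyond the scatter) in this assay, so for these two compounds it is where the hydroxyl sits on the phenyl ring that separates them, not whether a hydroxyl is present. Compound 4 also falls in with the compounds that lack a hydroxyl, with a 1.6-fold higher number from compound 2 to compound 4 (0.20 log units; within the scatter) for hydroxy in place of methyl and a 1.0-fold higher number from compound 1 to compound 4 (0.01 log units; within the scatter) for 3-hydroxyphenyl in place of thiophen-2-yl, and both steps stay within the scatter. A hydroxyl on the phenyl ring therefore does not by itself carry the number to the limit, and compound 3 alone stands at a limit of the assay, which is not a number: the limit of > 100000 nM in this assay, at which 1 of the 4 values shown sits.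

The compounds shown do not tell whether the effect belongs to the hydroxyl itself in compound 3, or whether a methoxy group or an amine in its place would also reach the limit. They also give no reason for the gap between the two hydroxyl positions, and 4-hydroxyphenyl remains an open case.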